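The source may hold more compounds than are shown below. What is called first, only, known or untested is meant among the compounds shown, and "the series" means these compounds.

Among the measured compounds shown here, compound 2 `C/C=C/C=C/C(=O)N[C@H](C(=O)NCCCCCCCCCCCCCC)[C@@H](C)O` is one of two compounds measured in a functional assay on HepG2 cells (Homo sapiens) for cytotoxicity, read by MTT assay, with a stated time of 48 h; on this read-out lower numbers stand for stronger inhibition and higher numbers for weaker inhibition. Compound 1 `CCCCCCCCCCCCCCNC(=O)[C@@H](NC(=O)c1cc2ccccc2o1)[C@@H](C)O` gives 23400 nM there. For compound 2 this assay reports only a limit, > 400000 nM; the limit of > 400000 nM in this assay, at which 1 of the 2 values shown sits, shows where that sits. Compound 3 `C/C=C/C=C/C(=O)N[C@H](C(=O)NCCCCCCCCCCCCCCCCCC)[C@@H](C)O` has not yet been measured and differs from compound 2 by butyl in place of hydrogen on a saturated chain carbon, ten or more bonds along the chain from an amide-type nitrogen. For the measured compounds named here, the only measured step, an at least 17-fold higher number from compound 1 to compound 2 (1.23 log units; beyond the scatter), concerns a different part of the molecule and leaves the chain untouched, so it offers no guide to a butyl in place of hydrogen; no step beyond the scatter is expected in this assay. Compound 3 is therefore expected to remain at the limit, estimated at 400000 nM, between 150000 nM and 1000000 nM, a step of a number no higher from compound 2 to compound 3 (the limit leaves the size open).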

Compound 3, half-maximal inhibitory concentration: 284000 nM
Beside the measured number, compound 3's estimate is 1.4-fold (0.15 log units) above it, within the range that was stated.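

Among the compounds shown here, this is the first view of the chain itself: in this assay, butyl in place of hydrogen on a saturated chain carbon, ten or more bonds along the chain from an amide-type nitrogen, produces an at least 1.4-fold lower number from compound 2 to compound 3 (0.14 log units; that floor lies within the scatter). With this change the compound gives a measured number, yet the floor of the step lies within the scatter, so no real gain is shown. Compound 2 carries only a limit, and the true size of the step stays open with it: the limit of > 400000 nM in this assay, at which 1 of the 3 values shown sits.

On these data alone, how an amine or a carboxylic acid at the end of the chain would read remains open. So does whether the same butyl would matter with the 1-benzofuran-2-yl group of compound 1.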